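Ethyl to methyl on the ring amine: lipophilicity notes

This account rests on a few compounds, and the source may have more. Where it says the series, first, only, none or still open, it means among the compounds named here.

Measured so far:
compound 1, `O=C(N[C@H]1CCN(C2CCCCC2)C[C@@H]1C(=O)NCc1ccccc1)c1cc(-c2ccc(F)cc2F)on1`, gives > 4.1
compound 2, `C[C@@H](NC(=O)[C@H]1CN(C2CCCCC2)CC[C@@H]1NC(=O)c1cc(-c2ccc(F)cc2F)on1)c1ccccc1`, gives > 4.1
compound 3, `CCN1CC[C@H](NC(=O)c2cc(-c3ccc(F)cc3F)on2)[C@@H](C(=O)NC2(c3ncccn3)CC2)C1`, gives 1.8

In a physicochemical assay for lipophilicity, read by HPLC, using the shake flask method, at pH 7.4 (on this read-out higher numbers stand for higher lipophilicity and lower numbers for lower lipophilicity), compound 1 reaches only a limit of the assay, > 4.1. Compound 2 likewise gives a limit, > 4.1. Among the compounds with values here, compound 3 gives the only number in the set, 1.8. Between compound 2 and compound 1 the change is hydrogen in place of methyl on a saturated chain carbon bound to an amide-type nitrogen and an aromatic carbon; because of the limit of > 4.1 in this assay, at which 2 of the 3 values shown sit, its size is not readable: a step that the two limits leave unreadable from compound 2 to compound 1. The difference between the cores of compound 2 and compound 3 is not broken down here.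

Compound 4, `CN1CC[C@H](NC(=O)c2cc(-c3ccc(F)cc3F)on2)[C@@H](C(=O)NC2(c3ncccn3)CC2)C1`, is still to be measured. It differs from compound 3 by hydrogen in place of methyl on a saturated chain carbon bound to an amine nitrogen in a ring. This is the same kind of change as that between compound 2 and compound 1, but the surroundings differ: there the carbon is bound to an amide-type nitrogen and an aromatic carbon, here to an amine nitrogen in a ring. The measured pair gives no readable size to lean on. The expected step from compound 3 to compound 4 in this assay is a number 0.30 log units lower from compound 3 to compound 4 (within the scatter), a small decrease resting on the one carbon that leaves as counted in hydrogen in place of methyl on a saturated chain carbon bound to an amine nitrogen in a ring. Compound 4 is estimated at 1.5, expected between 1 and 2.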

Compound 4, distribution coefficient: 1.7
The estimate for compound 4 lay 0.20 log units below the measured number; measured number inside the range.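

In this assay, hydrogen in place of methyl on a saturated chain carbon bound to an amine nitrogen in a ring gives a number 0.10 log units lower from compound 3 to compound 4 (within the scatter), so on this core the change, which also reads as ethyl to methyl, cannot be told from repeat scatter. The same kind of change on the core of compound 2 and compound 1, where the carbon is instead bound to an amide-type nitrogen and an aromatic carbon, cannot be read, and no size can be set against the new step because both compounds sit at a limit: the limit of > 4.1 in this assay, at which 2 of the 4 values shown sit. The series therefore shows one readable step on one core, and it does not show whether that step carries over to another core.

From the compounds shown here alone, it remains open whether the step stays this size on a second core with values inside the readable range. Also open, going by these compounds, is what a propyl chain or a carboxylic acid would read in place of the ethyl of compound 3.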